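Methoxy for phenyl on the carbonyl of compound 3

This account rests on a few compounds, and the source may have more. Where it says the series, first, only, none or still open, it means among the compounds named here.

In a functional assay on the whole organism with Homo sapiens as the target (on this read-out higher numbers stand for an effect only at larger amounts of compound and lower numbers for an effect already at smaller amounts), compound 1 (`CC(O)(C(=O)Nc1ccccc1Cl)C(F)(F)F`) gives 5400 nM, compound 2 (`CC(O)(C(=O)Nc1cccc(C(=O)c2ccccc2)c1)C(F)(F)F`) gives 10000 nM and compound 3 (`CC(O)(C(=O)Nc1cccc(C(=O)c2ccccc2)c1Cl)C(F)(F)F`) gives 11000 nM. Compound 3 thus sits at the high end of the three numbers, level with compound 2 and apart from compound 1.

The next structure is compound 4 (`COC(=O)c1cccc(NC(=O)C(C)(O)C(F)(F)F)c1Cl`), with methoxy in place of phenyl on a carbonyl carbon, so benzoyl to methoxycarbonyl: methoxy in place of phenyl on a carbonyl carbon.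

For the measured compounds named here, two measured steps bear on this. The benzoyl step, a 2.0-fold higher number from compound 1 to compound 3 (0.31 log units; beyond the scatter), is modest and the only one beyond the scatter. The chloro step, a 1.1-fold higher number from compound 2 to compound 3 (0.04 log units; within the scatter), is within the scatter, and compound 4 keeps that chloro. Going by the values given here, no measured compound carries methoxycarbonyl, so the size of this change is not directly covered. The benzoyl step of compound 1 to compound 3 (a 2.0-fold higher number from compound 1 to compound 3 (0.31 log units; beyond the scatter)) serves as the outer bound, and methoxycarbonyl is expected to land somewhere inside it. The expected change is a 1.4-fold lower number from compound 3 to compound 4 (0.14 log units; within the scatter), a small shift toward a lower number and probably not one that clears the scatter.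

For compound 4 the estimated value is 8000 nM, with an expected range of 3500 nM to 18000 nM.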

Compound 4, half-maximal effective concentration: 13800 nM
Estimate against measurement, compound 4: 1.7-fold (0.24 log units) below, within the range that was stated.
By their numbers in this assay, from the lowest: compounds 1, 2, 3 and 4 (each within the scatter of the next, the first and the last beyond it).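

Replacing phenyl with methoxy on a carbonyl carbon leaves the read-out in this assay level (a 1.3-fold higher number from compound 3 to compound 4 (0.10 log units; within the scatter)), so in this pair the six-membered aromatic ring of the benzoyl group is not needed to keep the number where compound 3 has it. Read against the hydrogen of compound 1, methoxycarbonyl gives a modest step beyond the scatter (a 2.6-fold higher number from compound 1 to compound 4 (0.41 log units; beyond the scatter)), on the same side as the benzoyl step (a 2.0-fold higher number from compound 1 to compound 3 (0.31 log units; beyond the scatter)), so both carbonyl groups shown here go with a higher number than hydrogen does, and neither brings an effect at smaller amounts of compound. Nothing on hand explains why the two groups read alike.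

Left open is whether a carboxylic acid, a primary amide or a longer chain such as ethoxy on the same carbonyl carbon would stay level with compound 4 or move away from it. Also open, on these data alone, is whether the chloro counts for anything alongside methoxycarbonyl, as it does not alongside benzoyl (a 1.1-fold higher number from compound 2 to compound 3 (0.04 log units; within the scatter)), and whether any group at this place gives a number lower than that of compound 1.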